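A few compounds are considered here, and "the series" means these few. Any claim that something is new, unique, unknown or untested is made for them only; others in the source may bear on it.

Compound 1 `Cc1cc(N2CCN(C(=O)Nc3nc4ccc(F)cc4s3)CC2)nnc1Cl` — > 10000 nM
Compound 2 `Cc1ccnnc1N1CCN(C(=O)Nc2nc3ccc(F)cc3s2)CC1` — > 25000 nM
Compound 3 `Cc1cnnc(N2CCN(C(=O)Nc3nc4ccc(F)cc4s3)CC2)c1` — not yet measured

Of the compounds shown here, two that share the same core have been tested in an assay on HEK293 cells for inhibition of transient receptor potential cation channel subfamily V member 1 (Homo sapiens), read by FLIPR, at pH 5.5; a lower number here means a stronger inhibitor, a higher number a weaker inhibitor. Compound 1 gives > 10000 nM, which is a limit of the assay rather than a number (the limit of > 10000 nM in this assay, at which 1 of the 2 values shown sits). Compound 2 gives > 25000 nM, again a limit rather than a number (the limit of > 25000 nM in this assay, at which 1 of the 2 values shown sits). The step that the two limits leave unreadable from compound 1 to compound 2 lies between two limits, so its size cannot be read.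

Compound 3 differs from compound 2 by 5-methylpyridazin-3-yl in place of 4-methylpyridazin-3-yl on an amine nitrogen in a ring. Within the data shown here, no measured step bears directly on this change: the only measured step, a step that the two limits leave unreadable from compound 1 to compound 2, involves a different exchange and has no readable size. Among the measured compounds shown here, compound 2 stands at a limit, and nothing among the measured values points toward a gain in potency when the methyl group is relocated. The expected step that the limit leaves unreadable from compound 2 to compound 3 is therefore none beyond the scatter. Compound 3 is expected to give about 30000 nM, most likely reported again as a limit. The expected range for compound 3 runs from 5000 nM to 100000 nM.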

Compound 3, half-maximal inhibitory concentration: > 10000 nM
Compound 3 ended at the assay's limit; the forecaster's own chance of this, stated with the estimate: 85%; the middle value lies beyond the limit too.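

In this assay, among these compounds, compound 1, compound 2 and compound 3 all stand at limits rather than numbers, so no step among them can be read: the limit of > 10000 nM in this assay, at which 2 of the 3 values shown sit. The compounds shown leave open whether 5-methylpyridazin-3-yl and 4-methylpyridazin-3-yl differ at all, and whether any compound with this shared core gives a measurable inhibition.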